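This account rests on a few compounds, and the source may have more. Where it says the series, first, only, none or still open, it means among the compounds named here.

Compound 1 `CO[C@@H]1[C@@H](OC)[C@H](c2ccccc2)O[C@@H]2CO[C@@H](c3ccccc3)O[C@@H]12` has in a functional assay on HEL cells (Homo sapiens) for cytotoxicity (on this read-out lower numbers stand for higher toxicity in this test and higher numbers for lower toxicity in this test), only the entry "not determined" (no result reported): no result was reported for it, so its place on this scale is open. The only figure at hand comes from compound 2 `O[C@@H]1[C@@H](O)[C@H](c2ccccc2)O[C@@H]2CO[C@@H](c3ccc(C(F)(F)F)cc3)O[C@@H]12`, which in this assay gives 35 ug/mL; that value is the sole anchor for where this family of compounds sits in the test.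

The step of interest leads from compound 1 to compound 3 `CO[C@@H]1[C@@H](OC)[C@H](c2ccccc2)O[C@@H]2CO[C@@H](c3ccc(C(F)(F)F)cc3)O[C@@H]12`. The change is small in atom count: trifluoromethyl in place of hydrogen on an aromatic carbon. Nothing in the shared core is touched, and only one position on one aromatic ring is altered.

There is no measured pair of this kind among the compounds shown. No direction can be read off the data. For the measured compounds named here, with only one number available at all, the honest expectation for this assay is that compound 3 will not depart from the region marked by compound 2 by more than the usual scatter, in either direction. Compound 3 is therefore expected to give about 35 ug/mL, with a plausible range from 10 ug/mL to 100 ug/mL.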

Compound 3, half-maximal cytotoxic concentration: > 50 ug/mL
Compound 3 was reported as a limit; the forecaster's own chance of this, stated with the estimate: 25%; middle value at least 1.4-fold (0.15 log units) away from the limit.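

In this assay compound 3 gives > 50 ug/mL, which is a limit and not a number. Compound 1 offers no number on this scale, and the step from compound 1 to compound 3 cannot be read. The compounds shown leave open whether trifluoromethyl in place of hydrogen changes the read-out at all, and in which direction.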